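The source may report more compounds than this note shows. Statements on the series, on what has been measured and on what is new or still open speak of the compounds shown alone.

Measured in a functional assay on HT-29 cells (Homo sapiens) for antiproliferative activity, read by sulforhodamine B assay, with a stated time of 48 h; a higher number here means a weaker inhibitor, a lower number a stronger inhibitor:
- Compound 1 `CC(C)(C)c1ccc(NS(=O)(=O)c2ccc(N3CCNC3=O)cc2)cc1`: > 1000 nM (a limit of the assay, not a number)
- Compound 2 `O=C1NCCN1c1ccc(S(=O)(=O)Nc2cccc(Br)c2)cc1`: 77 nM

Within the data shown here, compound 2 holds the only actual number so far, at 77 nM. Compound 1 sits at a limit of this assay, reported as > 1000 nM.

Compound 3 `O=C1NCCN1c1ccc(S(=O)(=O)Nc2ccc(Br)cc2)cc1` follows from compound 2 through one change, 4-bromophenyl in place of 3-bromophenyl on a sulfonamide nitrogen. Among the measured compounds shown here, no measured pair isolates this change, so the expectation is tentative: a moderate weakening in this assay, a little beyond the scatter. The estimated shift is a 2.6-fold higher number from compound 2 to compound 3 (0.41 log units; beyond the scatter). For compound 3 the expected value is 200 nM, with an estimated range from 50 nM to 900 nM.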

Compound 3, half-maximal inhibitory concentration: 300 nM
Beside the measured number, compound 3's estimate is 1.5-fold (0.18 log units) below it, within the range that was stated.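

On the sulfonamide nitrogen, 4-bromophenyl in place of 3-bromophenyl gives a 3.9-fold higher number from compound 2 to compound 3 (0.59 log units; beyond the scatter) in this assay, so the activity depends on where the bromine stands, even with the same atoms. Bromo in place of tert-butyl on an aromatic carbon gives an at least 3.3-fold lower number from compound 1 to compound 3 (0.52 log units; beyond the scatter). That step gives only a bound, as compound 1 is held at a limit and not a number: the limit of > 1000 nM in this assay, at which 1 of the 3 values shown sits.

Still open, on these data alone, is how an unsubstituted phenyl would compare with the two bromophenyl groups. As far as these compounds go, it is also open whether a chlorophenyl or methoxyphenyl group would show the same dependence on position.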